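Replacing a saturated chain with a triple bond

This account rests on a few compounds, and the source may have more. Where it says the series, first, only, none or still open, it means among the compounds named here.

- compound 1 `O=C(/C=C/c1ccc(NC(=O)Nc2ccc(Cl)c(C(F)(F)F)c2)cc1)NC1CCC1` with 4530 nM
- compound 2 `O=C(CCc1ccc(NC(=O)Nc2ccc(Cl)c(C(F)(F)F)c2)cc1)NC1CCC1` with 24000 nM

In a functional assay on MX1 cells (Homo sapiens) for inhibition, read by MTT assay, with a stated time of 120 h (a lower number here means a stronger inhibitor, a higher number a weaker inhibitor), compound 2 has the higher of the two numbers. Within the data shown here, the one measured step that bears on the next change is a 5.3-fold higher number from compound 1 to compound 2 (0.72 log units; beyond the scatter), where ethenyl gave way to ethyl in the chain. Compound 3 `CNC(=O)C#Cc1ccc(NC(=O)Nc2ccc(Cl)c(C(F)(F)F)c2)cc1` changes that chain again (2-(methylcarbamoyl)ethynyl in place of 2-(cyclobutylcarbamoyl)ethyl on an aromatic carbon). Among the measured compounds shown here, it regains a multiple bond, now a triple one, but loses the cyclobutyl ring, and no measured step covers that loss. Reversing part of a 5.3-fold higher number from compound 1 to compound 2 (0.72 log units; beyond the scatter), a lower number is expected, with wide uncertainty. The expected step is modest (a 3.4-fold lower number from compound 2 to compound 3 (0.54 log units; beyond the scatter)). Compound 3 is estimated at 7000 nM (2000 nM to 24000 nM).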

Compound 3, half-maximal inhibitory concentration: 26400 nM
Beside the measured number, compound 3's estimate is 3.8-fold (0.58 log units) below it; the whole stated range lies below it.
By their numbers in this assay, from the lowest: compound 1; then compounds 2 and 3 (each within the scatter of the next).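

The change to 2-(methylcarbamoyl)ethynyl brings back a multiple bond, yet it gives a 1.1-fold higher number from compound 2 to compound 3 (0.04 log units; within the scatter) in this assay and so no gain over the saturated chain. Set against the 2-(cyclobutylcarbamoyl)ethenyl chain, the same group gives a 5.8-fold higher number from compound 1 to compound 3 (0.77 log units; beyond the scatter) and so does not match compound 1. No measurement at hand explains these numbers.

The triple bond and the loss of the cyclobutyl ring come together here, so their shares stay unseparated. A 2-(cyclobutylcarbamoyl)ethynyl chain, keeping the ring with the triple bond, would be the direct test.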